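Adding a methoxy to compound 2

This account rests on a few compounds, and the source may have more. Where it says the series, first, only, none or still open, it means among the compounds named here.

In an ADME assay on CCRF-CEM cells (Homo sapiens) for antiproliferative activity, with a stated time of 48 h (a lower number here means a stronger inhibitor, a higher number a weaker inhibitor), compound 2 (`C=C(Br)C(=O)Nc1ccc(C(=O)/C=C/c2ccccc2)cc1`) gives 1500 nM and compound 1 (`C=C(Br)C(=O)Nc1ccc(/C=C/C(=O)c2ccc(Cl)c(Cl)c2)cc1`) gives 1700 nM so the two stand within the scatter of each other. Compound 3 (`C=C(Br)C(=O)Nc1ccc(C(=O)/C=C/c2ccccc2OC)cc1`) differs from compound 2 by methoxy in place of hydrogen on an aromatic carbon with methoxy in place of hydrogen on an aromatic carbon, ortho to a large group. For the measured compounds named here, no measured pair shows this change, so the expectation is loose: a small move toward a lower number, close to the scatter. The expected 1.5-fold lower number from compound 2 to compound 3 (0.18 log units; within the scatter) is of that size. Compound 3 is estimated at 1000 nM (expected range 300 nM to 3000 nM).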

Compound 3, half-maximal inhibitory concentration: 580 nM
Compound 3: middle estimate off by 1.7-fold (0.24 log units), on the high side, within the range that was stated.
By their numbers in this assay, from the lowest: compound 3; then compounds 2 and 1 (each within the scatter of the next).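

In this assay, methoxy in place of hydrogen on an aromatic carbon, ortho to a large group, gives a 2.6-fold lower number from compound 2 to compound 3 (0.41 log units; beyond the scatter). For the compounds shown here, this phenyl to 2-methoxyphenyl change is the first step that differs in one place, and it shows that this position responds to substitution by more than the scatter. No evidence at hand bears on the cause of this step.

Still open, from the compounds shown here alone, is whether a longer chain such as ethoxy, or an amine, on the same carbon moves the number in the same direction. Also open, going by these compounds, is whether methoxy on another carbon of this ring gives a similar step.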